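The source may hold more compounds than are shown below. What is called first, only, known or untested is meant among the compounds shown, and "the series" means these compounds.

Measured so far in a functional assay on CAKI-1 cells (Homo sapiens) for cytotoxicity, read by sulforhodamine B assay, with a stated time of 48 h; on this read-out higher numbers stand for weaker inhibition of growth and lower numbers for stronger inhibition of growth:
compound 1 `ClCc1cccc(Cn2cnc3ncnc(Cl)c32)c1`: 2130 nM
compound 2 `ClCc1ccc(Cn2cnc3nc(Cl)nc(Cl)c32)cc1`: 1440 nM
compound 3 `Nc1nc(Cl)c2ncn(Cc3cccc(CCl)c3)c2n1`: 240 nM

Compound 2 stands second highest of these three numbers. Its nearest neighbour is compound 1, whose number lies within the usual scatter, so no order between the two can be read. Compound 3 lies furthest away, with a clearly lower number, a gap beyond the scatter. Compound 4 `ClCc1ccc(Cn2cnc3ncnc(Cl)c32)cc1` has not yet been measured. It differs from compound 2 in one place: hydrogen in place of chloro on an aromatic carbon. For the measured compounds named here, no pair of measured compounds differs by exactly this change, so the size of the step is open. A step no larger than the scatter is expected, because compound 1 gives 2130 nM close to compound 2. The expected step is a 1.4-fold higher number from compound 2 to compound 4 (0.14 log units; within the scatter). Compound 4 is estimated at 2000 nM, within a range of 700 nM to 6000 nM.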

Compound 4, concentration for 50% growth inhibition: 1990 nM
Beside the measured number, compound 4's estimate is 1.0-fold (0.00 log units) above it; the range from low to high includes it.
By their numbers in this assay, from the lowest: compound 3; then compounds 2, 4 and 1 (each within the scatter of the next).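

Hydrogen in place of chloro on the aromatic carbon between two ring nitrogen atoms gives a 1.4-fold higher number from compound 2 to compound 4 (0.14 log units; within the scatter) in this assay and is the first step here that isolates a single change. At this position, then, the chloro group can be lost without a change that this read-out can separate from ordinary scatter. No measurement at hand explains this result.

Only hydrogen and chloro can be compared directly at this carbon, with the rest of the molecule held constant. Going by these compounds, how a methoxy group, a methyl group or a carboxylic acid there would read remains open.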